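This account rests on a few compounds, and the source may have more. Where it says the series, first, only, none or still open, it means among the compounds named here.

Of the compounds shown here, three so far have numbers in a functional assay on MCF7 cells (Homo sapiens) for cytotoxicity, read by MTT assay, with a stated time of 72 h; a lower number here means a stronger inhibitor, a higher number a weaker inhibitor. Compound 1 `Cn1ccc2c(Oc3ccc(NC(=O)c4nn(-c5ccc(Br)cc5)ccc4=O)cc3)ccnc21` gives 16300 nM, compound 2 `Cn1ccc2c(Oc3ccc(NC(=O)c4nn(-c5ccc(Cl)c(C(F)(F)F)c5)ccc4=O)cc3)ccnc21` gives 15200 nM, and compound 3 `Cn1ccc2c(Oc3ccc(NC(=O)c4nn(-c5ccc(Br)cc5)ccc4=O)cc3F)ccnc21` gives 33600 nM, the highest of the three. Two steps link them: the swap of 4-chloro-3-(trifluoromethyl)phenyl for 4-bromophenyl gave a 1.1-fold lower number from compound 1 to compound 2 (0.03 log units; within the scatter), while fluoro in place of hydrogen gave a 2.1-fold higher number from compound 1 to compound 3 (0.31 log units; beyond the scatter). For the measured compounds named here, compound 4 `Cn1ccc2c(Oc3ccc(NC(=O)c4nn(-c5ccc(Cl)c(C(F)(F)F)c5)ccc4=O)cc3F)ccnc21` applies the first of these swaps to compound 3: 4-chloro-3-(trifluoromethyl)phenyl in place of 4-bromophenyl on an aromatic nitrogen. Going by the values given here, the one measured step that bears on this change stayed within the scatter, so no step beyond the scatter is expected in this assay for compound 4. Compound 4 is expected at 32000 nM, with a range of 16000 nM to 64000 nM, an expected step of a 1.1-fold lower number from compound 3 to compound 4 (0.02 log units; within the scatter).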

Compound 4, half-maximal inhibitory concentration: 18400 nM
Compound 4: middle estimate off by 1.7-fold (0.24 log units), on the high side; the measured number falls inside the stated range.
By their numbers in this assay, from the lowest: compounds 2, 1, 4 and 3 (each within the scatter of the next, the first and the last beyond it).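

In this assay, 4-chloro-3-(trifluoromethyl)phenyl in place of 4-bromophenyl also stays within the scatter on the fluoro-bearing core, with a 1.8-fold lower number from compound 3 to compound 4 (0.26 log units; within the scatter), so this change can now be read on two cores: the same change on two cores in this assay, a 1.1-fold lower number (0.03 log units; within the scatter) from compound 1 to compound 2 and a 1.8-fold lower number (0.26 log units; within the scatter) from compound 3 to compound 4, 1.7-fold (0.23 log units) apart, within the scatter of two such steps. Fluoro in place of hydrogen also stays within the scatter when 4-chloro-3-(trifluoromethyl)phenyl is present, with a 1.2-fold higher number from compound 2 to compound 4 (0.08 log units; within the scatter), yet the two fluoro steps cannot be told apart: the same change on two cores in this assay, a 2.1-fold higher number (0.31 log units; beyond the scatter) from compound 1 to compound 3 and a 1.2-fold higher number (0.08 log units; within the scatter) from compound 2 to compound 4, 1.7-fold (0.23 log units) apart, within the scatter of two such steps.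

Open, on these data alone, is how an amine or a carboxylic acid on this phenyl would read in this assay. Also open, as far as these compounds go, is whether an alkyl chain on the aromatic nitrogen in place of phenyl would leave the numbers in this range.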